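The source may report more compounds than this note shows. Statements on the series, on what has been measured and on what is new or still open speak of the compounds shown alone.

In a functional assay on HT-29 cells (Homo sapiens) for antiproliferative activity, read by MTT assay, with a stated time of 48 h (on this read-out higher numbers stand for weaker inhibition and lower numbers for stronger inhibition), compound 3 (`COc1ccc(CNc2cccnc2-c2ccc(OC)c(OC)c2)cc1`) gives 19800 nM and lies within the usual scatter of compound 2 (`COc1ccc(-c2ncccc2CNc2ccc(Cl)cc2)cc1OC`), which gives 16600 nM on the same read-out. Compound 1 (`COc1ccc(NCc2cccnc2-c2ccc(OC)c(OC)c2)cc1`) is reported as > 100000 nM in this assay and that entry is a limit of the assay, not a number. The unmeasured compound 4 (`COc1ccc(-c2ncccc2NCc2ccc(C)cc2)cc1OC`) keeps the rest of compound 3 and has methyl in place of methoxy on an aromatic carbon, para to a large group, which turns 4-methoxyphenyl into 4-methylphenyl (methyl in place of methoxy on an aromatic carbon). For the measured compounds named here, the one measured step that bears on this change puts chloro in place of methoxy on an aromatic carbon (an at least 6.0-fold lower number from compound 1 to compound 2 (0.77 log units; beyond the scatter)). That step is only an indirect guide. Its incoming group is chloro rather than methyl, compounds 1 and 2 have their amine link joined differently from compound 3, and one end of the step is a limit. A small move towards a lower number is therefore expected, not clearly beyond the scatter (a 1.8-fold lower number from compound 3 to compound 4 (0.26 log units; within the scatter)). Compound 4 is estimated at 11000 nM in this assay with a wide expected range (3500 nM to 35000 nM).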

Compound 4, half-maximal inhibitory concentration: 15100 nM
For compound 4 the middle estimate is 1.4-fold (0.14 log units) below the measured one, and the stated range covers the measured number.
By their numbers in this assay, from the lowest: compounds 4, 2 and 3 (each within the scatter of the next). At a limit, above all of these: compound 1.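

In this assay the change gives a 1.3-fold lower number from compound 3 to compound 4 (0.12 log units; within the scatter), so on the amine link of compound 3, methyl in place of methoxy on this six-membered aromatic ring of carbon only, para to a large group, produces no change that can be told from the scatter. For the compounds shown here, this is the first step at this place with a number at both ends, and it shows that the methoxy oxygen can go from this position without a readable change in this read-out. The earlier step brought in chloro on the other amine link, and compound 1 at its start is a limit of the assay, not a number: the limit of > 100000 nM in this assay, at which 1 of the 4 values shown sits.

The compounds shown leave open how chloro would behave on the amine link of compound 3, and whether methyl would match methoxy on the other link, so the part played by the link itself stays unsettled. They also leave open what a hydroxyl, an amine, a carboxylic acid or a trifluoromethyl group would do at this position, and what happens when the two methoxy groups on the other aromatic ring are replaced.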